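The source may report more compounds than this note shows. Statements on the series, on what has been measured and on what is new or still open speak of the compounds shown alone.

Of the compounds shown here, three that share one saturated core have been measured in an assay on isolated protein for inhibition of Norepinephrine transporter (Rattus norvegicus), read by radioligand binding; on this read-out higher numbers stand for weaker inhibition and lower numbers for stronger inhibition. Compound 1 `CN1CCC(c2ccc(Cl)cc2)C(C[S+]([O-])CCO)C1` gives 42 nM. Compound 2 `COCCSCC1CN(C)CCC1c1ccc(Cl)cc1` gives 6 nM, and compound 3 `CC(=O)OCCSCC1CN(C)CCC1c1ccc(Cl)cc1` gives 3.6 nM. For the measured compounds named here, the change that leads to compound 2 brings a 7.0-fold lower number from compound 1 to compound 2 (0.85 log units; beyond the scatter), and the one leading to compound 3 brings a 12-fold lower number from compound 1 to compound 3 (1.07 log units; beyond the scatter). Between the last two the step is small: a 1.7-fold lower number from compound 2 to compound 3 (0.22 log units; within the scatter). So compound 3 stands far from compound 1 but cannot be separated from compound 2.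

Compound 4 `CN1CCC(c2ccc(Cl)cc2)C(CSCCOC(=O)c2ccccc2)C1` differs from compound 3 in one place: phenyl in place of methyl on a carbonyl carbon. Going by the values given here, the only measured step at this outer end of the chain is the one from compound 2 to compound 3, which stayed within the scatter, so a swap at the same end is expected to matter little in this assay. Among the compounds with values here, no measured pair shows a phenyl replacing a methyl, so the direction is uncertain, and the expected step is a 1.3-fold higher number from compound 3 to compound 4 (0.10 log units; within the scatter). Compound 4 is therefore expected to give about 4.5 nM, between 1.5 nM and 14 nM.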

Compound 4, inhibition constant: 4.5 nM
The estimate for compound 4 equals the measured number at the digits printed, within the range that was stated.
By their numbers in this assay, from the lowest: compounds 3, 4 and 2 (each within the scatter of the next); then compound 1.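

Phenyl in place of methyl on the carbonyl carbon brings an aromatic ring to the end of the chain, yet gives only a 1.3-fold higher number from compound 3 to compound 4 (0.10 log units; within the scatter), so in this assay this much larger group cannot be told apart from the small one. Benzoyl in place of methyl on the oxygen gives a 1.3-fold lower number from compound 2 to compound 4 (0.12 log units; within the scatter), so methyl, acetyl and benzoyl on that oxygen all read alike within the scatter. No measurement available here explains why these swaps leave the number so little changed.

The compounds shown leave open whether the number would stay in this range with an amine or a carboxylic acid at this end of the chain. They also leave open what a chlorobenzoyl group or a longer chain would do.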